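Chalcone amides: bromoacetyl and furoxan ether side chains

A few compounds are considered here, and "the series" means these few. Any claim that something is new, unique, unknown or untested is made for them only; others in the source may bear on it.

Measured so far:
compound 1 `O=C(CBr)Nc1ccc(C(=O)/C=C/c2ccc(Cl)cc2)cc1` gives 59%
compound 2 `COc1ccc(/C=C/C(=O)c2ccc(NC(=O)CBr)cc2)cc1` gives 46%
compound 3 `O=C(COCc1c(-c2ccccc2)no[n+]1[O-])Nc1ccc(C(=O)/C=C/c2ccc(Cl)cc2)cc1` gives 66%

All numbers come from a functional assay on the whole organism (strain albino) for inhibition, with Rattus norvegicus as the target, read by paw edema, with stated times of 30 min and 3 h, at a dose of 100 mg/kg by the oral route; a higher number here means more inhibition at the dose given (going by the name of the read-out), a lower number less inhibition. Compound 1 and compound 2 share one core and differ in a single place: methoxy in place of chloro on an aromatic carbon. That change gave a number 13 percentage points lower from compound 1 to compound 2 (beyond the scatter). Compound 3 carries another core; how the two cores differ is not broken down here. Compound 3 and compound 1 lie within the scatter of each other, while compound 2 sits beyond the scatter lower than compound 3.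

Compound 4, `COc1ccc(/C=C/C(=O)c2ccc(NC(=O)COCc3c(-c4ccccc4)no[n+]3[O-])cc2)cc1`, is not yet measured. It differs from compound 3 by methoxy in place of chloro on an aromatic carbon, the same change as that from compound 1 to compound 2, at the same place on the ring. The expectation for compound 4 in this assay rests on that one earlier step, which lowered the number: a number 13 percentage points lower from compound 1 to compound 2 (beyond the scatter). A step of comparable size is expected for compound 4, a number 13 percentage points lower from compound 3 to compound 4 (beyond the scatter). Compound 4 is therefore estimated at 53%, within 40% to 64%, on the footing of a single prior instance.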

Compound 4, a percentage reported as inhibition, in the whole organism at one dose (the size of the read-out at that dose, not a potency): 56%
Estimate against measurement, compound 4: 3 percentage points below; low and high end bracket the measured number.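

In this assay, within the data shown here, methoxy in place of chloro gives a number 10 percentage points lower from compound 3 to compound 4 (within the scatter), and set beside the earlier step, the change carries over between the two cores with much the same size: the same change on two cores in this assay, a number 13 percentage points lower (beyond the scatter) from compound 1 to compound 2 and a number 10 percentage points lower (within the scatter) from compound 3 to compound 4, 3 percentage points apart, within the scatter of two such steps Taken alone, however, the step on the second core does not stand clear of the usual scatter, so only the first step is a change that can be read by itself. Two cores and a single exchange of groups, read as inhibition at one oral dose, give no rule for other cores and say nothing of potency.

Still open, going by these compounds, is what a nitrile, an amine or a hydroxy group would do at the same place on the ring, and so whether the step belongs to methoxy specifically. Also open, on these data alone, is whether the step would keep this size with a longer chain or a carboxylic acid in the amide side chain.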